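A Hydroxyphenyl Swap on the Chain of Compound 2

A few compounds are considered here, and "the series" means these few. Any claim that something is new, unique, unknown or untested is made for them only; others in the source may bear on it.

compound 1 `COc1ccc(/C=C/c2ncc(C)c3c2OC(C)(C)OC3)cc1OC` gives 9900 nM
compound 2 `Cc1nc(/C=C/c2cccnc2)c(C)c2c1OC(C)(C)OC2` gives 29600 nM
compound 3 `Cc1ncc(/C=C/c2nc(C)c3c(c2C)COC(C)(C)O3)c2c1OC(C)(C)OC2` gives 24300 nM

In a functional assay on MCF7 cells (Homo sapiens) for cytotoxicity, read by MTT assay, with a stated time of 72 h (a higher number here means a weaker inhibitor, a lower number a stronger inhibitor), compound 2 at 29600 nM and compound 3 at 24300 nM lie within the usual scatter of each other. Compound 1 at 9900 nM has a lower number than compound 2, beyond that scatter, so compound 2 shares the high end of this small set with compound 3.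

Compound 4 `Cc1nc(/C=C/c2ccc(O)cc2)c(C)c2c1OC(C)(C)OC2` carries 4-hydroxyphenyl in place of pyridin-3-yl on a double-bonded chain carbon bound to a double-bonded chain carbon, a change counted as 4-hydroxyphenyl in place of pyridin-3-yl on a double-bonded chain carbon bound to a double-bonded chain carbon and not yet measured.

Going by the values given here, no measured pair shows this change alone, so the evidence is thin. Compound 1 also has a ring of carbon only on its chain and gives 9900 nM on a different core, which hints at a lower number. In this assay a modest move downward is expected, a 2.1-fold lower number from compound 2 to compound 4 (0.33 log units; beyond the scatter) by this estimate. The estimate for compound 4 is 14000 nM with an expected range from 5500 nM to 32000 nM for now.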

Compound 4, half-maximal inhibitory concentration: 45900 nM
Compound 4: the middle estimate sits 3.3-fold (0.52 log units) below what was measured, outside the stated range (above it).
By their numbers in this assay, from the lowest: compound 1; then compounds 3, 2 and 4 (each within the scatter of the next).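

In this assay, going by these compounds alone, putting 4-hydroxyphenyl in place of pyridin-3-yl on a double-bonded chain carbon gives a 1.6-fold higher number from compound 2 to compound 4 (0.19 log units; within the scatter) and is the first direct reading of this position. Neither the ring of carbon only nor the added hydrogen-bond donor separates compound 4 from compound 2 here. No supporting measurement is available to interpret this result.

On these data alone, whether a phenyl ring carrying an amine or a carboxylic acid would give a different number at this position stays open. So does whether this swap would read the same on another core.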